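The source may report more compounds than this note shows. Statements on the series, on what has been measured and on what is new or still open speak of the compounds shown alone.

Three adenosine-triphosphate derivatives carrying an iodoacetamide group on a chain at the purine nitrogen were tested in an assay on isolated protein for inhibition of hexokinase-1 (Rattus norvegicus), with a stated time of 6 h, tested at 10 mM; on this read-out lower numbers stand for less inhibition and higher numbers for more inhibition at the one concentration tested (going by the name of the read-out). Compound 1 `O=C(CI)NCCCCCCCCNc1ncnc2c1ncn2[C@@H]1O[C@H](COP(=O)(O)OP(=O)(O)OP(=O)(O)O)[C@@H](O)[C@H]1O` gives 35%, compound 2 `O=C(CI)NCCCCNc1ncnc2c1ncn2[C@@H]1O[C@H](COP(=O)(O)OP(=O)(O)OP(=O)(O)O)[C@@H](O)[C@H]1O` gives 0%, and compound 3 `O=C(CI)NCCCC(=O)NCCCCCCNc1ncnc2c1ncn2[C@@H]1O[C@H](COP(=O)(O)OP(=O)(O)OP(=O)(O)O)[C@@H](O)[C@H]1O` gives 0%. Among the compounds with values here, compound 3 therefore stands level with compound 2, the two together being the lowest of the three numbers, and its only distance is to compound 1, whose value sits well higher.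

Compound 4 `O=C(I)NCC(=O)NCCCCCCNc1ncnc2c1ncn2[C@@H]1O[C@H](COP(=O)(O)OP(=O)(O)OP(=O)(O)O)[C@@H](O)[C@H]1O` is the next member. Relative to compound 3 the change is a group of 4 heavy atoms (1 carbon, 1 nitrogen, 1 oxygen, 1 iodine; no ring) in place of a group of 7 heavy atoms (4 carbon, 1 nitrogen, 1 oxygen, 1 iodine; no ring), on a saturated chain carbon bound to a carbonyl carbon. Within the data shown here, two measured steps bear on this. Shortening the chain gave a number 35 percentage points lower from compound 1 to compound 2 (beyond the scatter), and inserting an amide into a longer chain gave a number 35 percentage points lower from compound 1 to compound 3 (beyond the scatter). Both changes to compound 1 wiped out its inhibition, and compound 3 already shows none. Compound 4 shortens the chain of compound 3 further, which leaves no room to fall and gives no reason to expect a rise.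

Compound 4 is therefore expected to give about 4% in this assay, within a range from 0% to 18%. That expectation means a step of a number 4 percentage points higher from compound 3 to compound 4 (within the scatter), within the scatter.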

Compound 4, a percentage reported as inhibition, at one concentration (the size of the read-out at that concentration, not a potency): 0%
Compound 4: middle estimate off by 4 percentage points, on the high side; the range from low to high includes it.
By their numbers in this assay, from the lowest: compounds 2, 3 and 4 (each within the scatter of the next); then compound 1.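

In this assay, swapping the 2-(((iodomethyl)carbonyl)amino)ethyl group on this saturated chain carbon bound to a carbonyl carbon for the smaller group of 4 heavy atoms gives no change at the digits printed from compound 3 to compound 4 (within the scatter), so cutting back this end of the chain brings no inhibition back. The comparison with the shorter unbroken chain reads no change at the digits printed from compound 2 to compound 4 (within the scatter), while the comparison with the long unbroken chain reads a number 35 percentage points lower from compound 1 to compound 4 (beyond the scatter), which leaves compound 1 as the only one of the four with a reading beyond the scatter of the others. Nothing available explains why these chains differ in this way.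

Compound 2, compound 3 and compound 4 all sit at the bottom of the read-out, so these numbers cannot separate them or show whether this last change has any effect of its own. From the compounds shown here alone, it remains open whether a longer chain containing the same inner amide would restore inhibition, and whether the iodine-bearing end matters, which a chain like that of compound 1 ending in a plain amine or a carboxylic acid could test.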